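Compound 1 to compound 3: one group exchanged

This account rests on a few compounds, and the source may have more. Where it says the series, first, only, none or still open, it means among the compounds named here.

In a physicochemical assay for solubility, with a stated time of 24 h, at pH 2.2 (on this read-out higher numbers stand for higher solubility and lower numbers for lower solubility), compound 1 (`O=C(NC[C@@H]1[C@H]2CN(C(=O)CCc3cc(Cl)cc(Cl)c3)C[C@@H]12)c1ccc2[nH]c(=O)oc2c1`) gives < 1 ug/mL, which is a limit of the assay and not a number. Compound 2 (`O=C(NC[C@@H]1[C@H]2CN(C(=O)OCc3cc(C(F)(F)F)cc(C(F)(F)F)c3)C[C@@H]12)c1ccc2[nH]c(=O)oc2c1`) gives < 1 ug/mL, which is also a limit. Together they make up all the evidence so far: the limit of < 1 ug/mL in this assay, at which 2 of the 2 values shown sit. No measured number therefore marks where compound 1 truly stands.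

Compound 3 (`Cc1cc(COC(=O)N2C[C@@H]3[C@@H](CNC(=O)c4ccc5[nH]c(=O)oc5c4)[C@@H]3C2)no1`) keeps the shared core and changes one group: (5-methyl-1,2-oxazol-3-yl)methoxy in place of 2-(3,5-dichlorophenyl)ethyl on a carbonyl carbon. In words, (5-methyl-1,2-oxazol-3-yl)methoxy stands in place of 2-(3,5-dichlorophenyl)ethyl on a carbonyl carbon. The six-membered aromatic ring of carbon only and its chlorine atoms leave, and a five-membered aromatic ring with hetero atoms enters, along with hydrogen-bond acceptors.

Within the data shown here, no measured step between two compounds is available as a guide, so this forecast rests on the structural change alone. In this assay, an upward move beyond the usual scatter is expected, with an estimated size of an at least 12-fold higher number from compound 1 to compound 3 (1.07 log units; beyond the scatter). The estimated solubility of compound 3 is 12 ug/mL, with an expected range from 2 ug/mL to 80 ug/mL.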

Compound 3, solubility: > 86 ug/mL
Compound 3 ended at the assay's limit; the forecaster's own chance of this, stated with the estimate: 15%; middle value at least 7.1-fold (0.85 log units) from the limit.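

With (5-methyl-1,2-oxazol-3-yl)methoxy in place of 2-(3,5-dichlorophenyl)ethyl on a carbonyl carbon whose other neighbours are an amide-type nitrogen in a ring, this assay shows an at least 86-fold higher number from compound 1 to compound 3 (1.93 log units; beyond the scatter), so a single exchange at this position can go with a large difference in the read-out, something the two earlier values, both at the same limit, could not show. Compound 3 stands at a limit of the assay, not at a number: the limit of > 86 ug/mL in this assay, at which 1 of the 3 values shown sits. Compound 1 also stands at a limit of the assay, not at a number: the limit of < 1 ug/mL in this assay, at which 2 of the 3 values shown sit.

On these data alone, the true size of the step stays open, and so does which part of the exchange goes with it, since the six-membered aromatic ring of carbon only and its chlorine atoms leave together as the five-membered aromatic ring with hetero atoms enters. The compounds shown also leave open how a chain ending in an amine or a carboxylic acid on this same carbonyl carbon would read in this assay.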